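Urea aryl swap on the benzothiazole ether series

The compounds below may be only part of what the source reports. "The series", "measured", "known", "first", "only" and "open" are said of these compounds alone.

Measured so far:
compound 1 `O=C(Nc1nc2ccc(Oc3ccc(F)c(NC(=O)C4(c5cccc(C(F)(F)F)c5)CC4)c3)cc2s1)C1CC1` — in an assay for binding affinity to receptor-interacting serine/threonine-protein kinase 3 (Homo sapiens), read by KINOMEscan and polymerase chain reaction, with a stated time of 1 h (a lower number here means tighter binding, a higher number weaker binding), compound 1 is reported as "not determined" (no result reported)
compound 2 `CCOC(=O)c1cccc(NC(=O)Nc2cc(Oc3ccc4nc(NC(=O)C5CC5)sc4c3)ccc2F)c1` — 72 nM

Compound 1 has no number in this assay, so compound 2 is the only anchor: in this assay compound 2 gives 72 nM, and it stands alone, with nothing to rank it against. Within the data shown here, no step between two measured compounds is available.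

Compound 3 `COc1cccc(NC(=O)Nc2cc(Oc3ccc4nc(NC(=O)C5CC5)sc4c3)ccc2F)c1` is not yet measured. It differs from compound 2 in one place: methoxy in place of ethoxycarbonyl on an aromatic carbon — methoxy in place of ethoxycarbonyl on an aromatic carbon, meta to a large group. Among the measured compounds shown here, with the ester gone and only a methoxy remaining on the urea-bearing ring, the change is small in heavy-atom count, and with no measured step to lean on, the expected step from compound 2 to compound 3, a 2.1-fold higher number from compound 2 to compound 3 (0.32 log units; beyond the scatter), is taken as a modest weakening that may still fall within the scatter. The estimate for compound 3 is 150 nM, with a range from 40 nM to 600 nM.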

Compound 3, dissociation constant: 69 nM
Beside the measured number, compound 3's estimate is 2.2-fold (0.34 log units) above it, within the range that was stated.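

In this assay, exchanging ethoxycarbonyl for methoxy on this aromatic carbon gives a 1.0-fold lower number from compound 2 to compound 3 (0.02 log units; within the scatter), so the two compounds do not separate. Among these compounds, this is the first reading at this position, and it shows that going from 3-(ethoxycarbonyl)phenyl to 3-methoxyphenyl, a smaller group with fewer hydrogen-bond acceptors and no double bond outside the aromatic rings, leaves the binding reading within the scatter. No measurement in hand accounts for the two compounds reading alike.

From the compounds shown here alone, whether a carboxylic acid, an amine or a longer ether chain on the same aromatic carbon would also stay within the scatter of compound 3 remains open, as does the plain phenyl with no group there at all. Compound 1 has no numerical result in this assay, so its trifluoromethyl-bearing amide offers no comparison with the urea compounds, and the contribution of the urea itself remains unread.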